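The compounds below may be only part of what the source reports. "The series", "measured", "known", "first", "only" and "open" are said of these compounds alone.

Working notes on the series.

In an assay on isolated protein for inhibition of Rho-associated protein kinase 2 (Homo sapiens) (a lower number here means a stronger inhibitor, a higher number a weaker inhibitor), compound 1 `COc1cccc(CN(C)C(=O)c2c[nH]c3cc(-c4cn[nH]c4)ccc23)c1` gives 2 nM. Compound 2 `COc1cccc(CN(C)C(=O)c2cc3ccc(-c4cn[nH]c4)nc3[nH]2)c1` has a core that differs from that of compound 1; in this assay compound 2 gives 4 nM. Compound 3 `COc1cccc(CNC(=O)c2cc3ccc(-c4cn[nH]c4)nc3n2CCN(C)C)c1` carries a 2-(dimethylamino)ethyl on the aromatic nitrogen of the shared core of compound 2 and a secondary amide; in this assay compound 3 gives 43 nM, the highest of the three numbers, with both gaps to compound 1 and compound 2 lying beyond the scatter.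

Compound 4 `COc1cccc(CNC(=O)c2cc3ccc(-c4cn[nH]c4)nc3n2CC2CC2)c1` is the next compound to be measured in this assay. It differs from compound 3 in one place: cyclopropyl in place of (dimethylamino)methyl on a saturated chain carbon bound to an aromatic nitrogen. Within the data shown here, no measured pair shows this change, so there is no step to rest on; the only anchor is the value of compound 3 in this assay, which already stands at the weak end of the series. The expectation for compound 4 is a small step, a 1.2-fold higher number from compound 3 to compound 4 (0.07 log units; within the scatter), not clearly beyond the scatter in either direction. Compound 4 is therefore estimated at 50 nM in this assay, with a range from 15 nM to 160 nM.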

Compound 4, half-maximal inhibitory concentration: 150 nM
For compound 4 the middle estimate is 3.0-fold (0.48 log units) below the measured one; the range from low to high includes it.
By their numbers in this assay, from the lowest: compounds 1 and 2 (each within the scatter of the next); then compound 3; then compound 4.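

In this assay, the group on the aromatic nitrogen of the shared core matters: with the secondary amide unchanged, cyclopropyl in place of (dimethylamino)methyl gives a 3.5-fold higher number from compound 3 to compound 4 (0.54 log units; beyond the scatter). Among these compounds, this is the first one-place step, and it favours the 2-(dimethylamino)ethyl chain over cyclopropylmethyl. Nothing on hand bears on why the number moves.

The change removes a nitrogen and adds a three-membered ring in one move, so the compounds shown do not separate the contribution of either. Going by these compounds, a plain propyl chain, a 2-methoxyethyl chain or a 2-(pyrrolidin-1-yl)ethyl chain on the same nitrogen would address this, and whether a longer chain ending in dimethylamino moves the number further also remains open.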